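The source may hold more compounds than are shown below. What is called first, only, known or untested is meant among the compounds shown, and "the series" means these compounds.

Of the compounds shown here, three share one core and have been tested in a functional assay on PC-3 cells (Homo sapiens) for cytotoxicity, read by MTT assay, with a stated time of 72 h; a higher number here means a weaker inhibitor, a lower number a stronger inhibitor. Compound 1 `O=C(Nc1nc2ccccc2s1)c1cn(-c2ccccc2)nc1-c1ccccc1` gives 10400 nM in this assay. Compound 2 `O=C(Nc1nc2ccc(Cl)cc2s1)c1cn(-c2ccccc2)nc1-c1ccccc1`, which carries a chloro on the fused ring, gives 3690 nM. Compound 3 `O=C(Nc1nc2ccccc2s1)c1cn(-c2ccccc2)nc1-c1ccc(F)cc1`, which carries a fluoro on the outer phenyl ring, gives 7130 nM. Among these three numbers compound 3 stands second highest: its gap to compound 1 is within the scatter, and its gap to compound 2 is within the scatter as well, so no order can be claimed between compound 3 and either neighbour.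

Compound 4 `Cc1ccc2nc(NC(=O)c3cn(-c4ccccc4)nc3-c3ccc(F)cc3)sc2c1` has not yet been measured. It differs from compound 3 in one place: methyl in place of hydrogen on an aromatic carbon, which turns the 1,3-benzothiazol-2-yl group into a 6-methyl-1,3-benzothiazol-2-yl group. The step that bears most on this is a 2.8-fold lower number from compound 1 to compound 2 (0.45 log units; beyond the scatter), where a chloro entered the same fused ring; the other step, a 1.5-fold lower number from compound 1 to compound 3 (0.16 log units; within the scatter), concerns the phenyl ring and stayed within the scatter. A methyl is a different group from a chloro, so only a modest move is expected, towards a lower number, expressed as a 1.6-fold lower number from compound 3 to compound 4 (0.20 log units; within the scatter). Compound 4 is therefore estimated at 4500 nM in this assay, with a plausible range from 2000 nM to 10000 nM.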

Compound 4, half-maximal inhibitory concentration: 20500 nM
Compound 4: middle estimate off by 4.6-fold (0.66 log units), on the low side; the whole stated range lies below it.
By their numbers in this assay, from the lowest: compounds 2, 3, 1 and 4 (each within the scatter of the next, the first and the last beyond it).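

In this assay, the fused ring of the shared core is not a place where any added group helps: the step of a 2.9-fold higher number from compound 3 to compound 4 (0.46 log units; beyond the scatter) runs in the opposite direction to the step of a 2.8-fold lower number from compound 1 to compound 2 (0.45 log units; beyond the scatter), and both lie beyond the scatter. Going by these compounds alone, until now, the only change on this ring had been a chloro, which lowered the number, so a single result could suggest that filling this spot was favourable in general. The methyl shows that the outcome depends on which group enters, although the two steps start from different compounds, since the methyl was added to a core that already carries a fluoro on the outer phenyl ring.

The compounds shown leave open whether a methyl on this ring would raise the number without that fluoro, and where a group such as an amine, a carboxylic acid or a longer chain at the same spot would fall. No measurement here explains why the chloro and the methyl move the number in opposite directions.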